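This account rests on a few compounds, and the source may have more. Where it says the series, first, only, none or still open, it means among the compounds named here.

Measured so far:
- Compound 1, `Cc1c(C(=O)N/N=C\c2cc(F)ccc2O)oc2cccc(O)c12`: 3170 nM
- Compound 2, `Cc1c(C(=O)N/N=C\c2cc(O)ccc2O)oc2cccc(O)c12`: 95500 nM
- Compound 3, `Cc1c(C(=O)N/N=C\c2c(O)cccc2Cl)oc2cccc(O)c12`: 18700 nM

These three share one core and differ only in the aryl group attached to the carbon with a double bond to nitrogen. In a functional assay on PC-3 cells (Homo sapiens) for inhibition (on this read-out higher numbers stand for weaker inhibition and lower numbers for stronger inhibition), compound 1 gives 3170 nM and is the strongest inhibitor of the three. Compound 3 stands second highest: it lies a 5.9-fold higher number from compound 1 to compound 3 (0.77 log units; beyond the scatter) and a 5.1-fold lower number from compound 2 to compound 3 (0.71 log units; beyond the scatter).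

Compound 4, `Cc1c(C(=O)N/N=C\c2ccccc2F)oc2cccc(O)c12`, has not yet been measured. It differs from compound 3 in one place: 2-fluorophenyl in place of 2-chloro-6-hydroxyphenyl on a carbon with a double bond to nitrogen.

Going by the values given here, two measured steps bear on this change, since both swap the whole aryl group at the same place: a 5.9-fold higher number from compound 1 to compound 3 (0.77 log units; beyond the scatter) and a 5.1-fold lower number from compound 2 to compound 3 (0.71 log units; beyond the scatter). Both show that exchanging this aryl group moves this assay by a modest amount. The step of a 30-fold higher number from compound 1 to compound 2 (1.48 log units; beyond the scatter) shows that adding a hydroxy group weakened inhibition by a large amount, and compound 4 has no hydroxy group on its aryl ring, so a modest move toward a lower number is expected. Among the compounds with values here, the data hold no compound lacking a hydroxy group on that ring, so the estimate is uncertain. Compound 4 is expected at 8000 nM, within 2000 nM to 40000 nM, a step of a 2.3-fold lower number from compound 3 to compound 4 (0.37 log units; beyond the scatter).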

Compound 4, half-maximal inhibitory concentration: >= 40000 nM
Compound 4 ended at the assay's limit (the forecaster's own chance of this, stated with the estimate: 5%); at least 5.0-fold (0.69 log units) between middle value and limit.
By their numbers in this assay, from the lowest: compound 1; then compound 3; then compound 2.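

In this assay the reading of compound 4 is a limit of the assay and not a number: the limit of >= 40000 nM in this assay, at which 1 of the 4 values shown sits. Even so, the direction is clear, and it is new: with 2-fluorophenyl on the carbon with a double bond to nitrogen, the one ring here without a hydroxy group does not give stronger inhibition, as an at least 2.1-fold higher number from compound 3 to compound 4 (0.33 log units; beyond the scatter) and an at least 12-fold higher number from compound 1 to compound 4 (1.10 log units; beyond the scatter) both show. The weak result for compound 2 therefore cannot be read as a general penalty for a hydroxy group on this ring, and the fluoro group of compound 4 alone does not reproduce the stronger inhibition of compound 1, so the outcome depends on the whole pattern of groups on the ring rather than on one group.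

From the compounds shown here alone, the steps between compound 2 and compound 4 cannot be read at this limit, so the order of those two stays open. Also open, going by these compounds, is how a plain phenyl, a 2-hydroxyphenyl, a methoxy group or an amine on this ring would behave, and so which part of the 5-fluoro-2-hydroxyphenyl group of compound 1 carries its stronger inhibition.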